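Pyrazinylmethyl in place of thiophenylmethyl on a thiazolopyrimidine amine

This account rests on a few compounds, and the source may have more. Where it says the series, first, only, none or still open, it means among the compounds named here.

Compound 1 `Nc1nc(NCc2ccco2)nc2sc(-c3ccco3)nc12`: 4.72 nM
Compound 2 `Nc1nc(NCc2ccccn2)nc2sc(-c3ccco3)nc12`: 59 nM
Compound 3 `Nc1nc(NCc2ccsc2)nc2sc(-c3ccco3)nc12`: 3.14 nM

In an assay on CHO cells for displacement of a labelled ligand from adenosine receptor A3 (Homo sapiens), read by scintillation counting, with a stated time of 120 min (on this read-out lower numbers stand for stronger inhibition and higher numbers for weaker inhibition), compound 3 gives 3.14 nM, the lowest number among the three measured compounds. Its gap to compound 1 is small: a 1.5-fold lower number from compound 1 to compound 3 (0.18 log units; within the scatter), so the two cannot be ranked against each other. Compound 2, by contrast, stands well apart: a 19-fold lower number from compound 2 to compound 3 (1.27 log units; beyond the scatter), and likewise a 13-fold higher number from compound 1 to compound 2 (1.10 log units; beyond the scatter).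

Compound 4 `Nc1nc(NCc2cnccn2)nc2sc(-c3ccco3)nc12` has not been measured. It differs from compound 3 in one place: pyrazin-2-yl in place of thiophen-3-yl on a saturated chain carbon bound to a nitrogen on an aromatic ring. Among the compounds with values here, the step that bears on this change most directly is the one from compound 2 to compound 3, since pyridin-2-yl, like pyrazin-2-yl, is a six-membered aromatic ring bearing a ring nitrogen, whereas the five-membered furan-2-yl and thiophen-3-yl give the low numbers. The step from compound 3 to compound 4 is therefore expected to be large and upward in this assay, roughly the reverse of the change from compound 2 to compound 3, with the second ring nitrogen adding some uncertainty: a 25-fold higher number from compound 3 to compound 4 (1.41 log units; beyond the scatter). Compound 4 is thus estimated at 80 nM, within a range of 20 nM to 320 nM.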

Compound 4, inhibition constant: 157 nM
Compound 4: the middle estimate sits 2.0-fold (0.29 log units) below what was measured; measured number inside the range.
By their numbers in this assay, from the lowest: compounds 3 and 1 (each within the scatter of the next); then compound 2; then compound 4.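

In this assay the pyrazin-2-yl group gives the highest number of the four compounds, with a 50-fold higher number from compound 3 to compound 4 (1.70 log units; beyond the scatter) and a 33-fold higher number from compound 1 to compound 4 (1.52 log units; beyond the scatter) as the steps from the two five-membered rings. Both six-membered rings now stand on the high side of both five-membered rings, so the gap seen with pyridin-2-yl alone is no longer a single case, and none of the four compounds goes against this. The step between the two six-membered rings is much smaller but still counts, at a 2.7-fold higher number from compound 2 to compound 4 (0.43 log units; beyond the scatter) and with 2 hetero atoms in the entering ring; nothing measured here accounts for these differences. The compounds shown leave open where a plain phenyl ring, with no ring nitrogen, would fall. They also leave open whether a longer chain carrying the same rings would keep this order.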